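Nitro to amino on the methoxy-bearing ring

The source may hold more compounds than are shown below. What is called first, only, known or untested is meant among the compounds shown, and "the series" means these compounds.

- compound 1 `COc1ccc(CN(C(=O)CSC(=S)N2CCN(C(=O)OC(C)(C)C)CC2)c2cc(OC)c(OC)c(OC)c2)cc1C`: > 20000 nM
- compound 2 `COc1ccc(CN(C(=O)CSC(=S)N2CCN(C(=O)OC(C)(C)C)CC2)c2cc(OC)c(OC)c(OC)c2)cc1[N+](=O)[O-]`: 980 nM

For the measured compounds named here, in a functional assay on HCT-116 cells (Homo sapiens) for inhibition, read by CCK-8 assay, with a stated time of 48 h (a higher number here means a weaker inhibitor, a lower number a stronger inhibitor), compound 2 gives 980 nM, the only true number so far. Compound 1 gives > 20000 nM, which is a limit of the assay and not a number. The next compound is compound 3 `COc1ccc(CN(C(=O)CSC(=S)N2CCN(C(=O)OC(C)(C)C)CC2)c2cc(OC)c(OC)c(OC)c2)cc1N`, with amino in place of nitro on an aromatic carbon, ortho to a methoxy group: amino in place of nitro on an aromatic carbon.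

Going by the values given here, only one measured step bears on this place: nitro in place of methyl gave an at least 20-fold lower number from compound 1 to compound 2 (1.30 log units; beyond the scatter). From the compounds shown here alone, that step starts from the limit of > 20000 nM in this assay, at which 1 of the 2 values shown sits, so its full size is unknown. It shows that a swap here can matter greatly, but it involves no amino group and fixes no direction for this change. The best guess therefore stays close to compound 2, with a wide range on both sides. Compound 3 is expected at 800 nM, with an estimated range of 150 nM to 5000 nM. This estimate means an expected 1.2-fold lower number from compound 2 to compound 3 (0.09 log units; within the scatter).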

Compound 3, half-maximal inhibitory concentration: 352 nM
For compound 3 the middle estimate is 2.3-fold (0.36 log units) above the measured one; measured number inside the range.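

In this assay, the position on the methoxy-bearing ring does not depend on nitro, since amino in its place gives a 2.8-fold lower number from compound 2 to compound 3 (0.44 log units; beyond the scatter). That is a modest step, but it shows that a group with one heavy atom and a hydrogen-bond donor can serve here at least as well as nitro, so the gain over methyl is not unique to nitro. Amino in place of methyl gives an at least 56-fold lower number from compound 1 to compound 3 (1.75 log units; beyond the scatter), and the true size of that step cannot be read, because compound 1 sits at a limit of the assay and not at a number: the limit of > 20000 nM in this assay, at which 1 of the 3 values shown sits.

From the compounds shown here alone, whether the hydrogen-bond donor of amino is what matters stays open, and a hydroxyl, a methylamino or an acetamide group at this position would bear on that. Going by these compounds, how far a larger group on this carbon would still fit the trend also remains unknown.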